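Working notes on a methyl to trifluoromethyl step

The source may report more compounds than this note shows. Statements on the series, on what has been measured and on what is new or still open speak of the compounds shown alone.

Measured compounds:
compound 1 `CNc1nc(C)c(C(=O)N/N=C/c2cccc(C(F)(F)F)c2)s1` gives > 100 ug/mL
compound 2 `CNc1nc(C(F)(F)F)c(C(=O)N/N=C/c2cccc(C(F)(F)F)c2)s1` gives > 100 ug/mL
compound 3 `Cc1nc(N(C)C(=O)NC(=O)c2c(F)cccc2F)sc1C(=O)N/N=C/c1cc(C(F)(F)F)cc(C(F)(F)F)c1` gives 11.4 ug/mL

In a functional assay on HepG2 cells (Homo sapiens) for inhibition, read by MTT assay, with a stated time of 72 h (on this read-out lower numbers stand for stronger inhibition and higher numbers for weaker inhibition), compound 1 gives > 100 ug/mL, which is a limit of the assay and not a number. Compound 2 gives > 100 ug/mL in this assay, again a limit and not a number. Going by the values given here, compound 3 gives 11.4 ug/mL in this assay, the only number among the three. The change from compound 1 to compound 2 is trifluoromethyl in place of methyl on an aromatic carbon; the resulting step is a step that the two limits leave unreadable from compound 1 to compound 2, and its size is not readable because of the limit of > 100 ug/mL in this assay, at which 2 of the 3 values shown sit. The difference between the core of compound 1 and the core of compound 3 is not broken down here.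

Compound 4 `CN(C(=O)NC(=O)c1c(F)cccc1F)c1nc(C(F)(F)F)c(C(=O)N/N=C/c2cc(C(F)(F)F)cc(C(F)(F)F)c2)s1` is not yet measured. It differs from compound 3 by trifluoromethyl in place of methyl on an aromatic carbon. Among the compounds with values here, this is the same kind of change as the one from compound 1 to compound 2, though the surroundings differ: in the earlier pair the ring atom two bonds away bears a methylamino group, whereas here it bears a large group.

Within the data shown here, since the one measured instance of this change leaves no readable size, the step from compound 3 to compound 4 is expected to be small, estimated as a 1.1-fold higher number from compound 3 to compound 4 (0.02 log units; within the scatter), resting on compound 3 at 11.4 ug/mL as the only anchor. Compound 4 is therefore estimated at 12 ug/mL in this assay, with an expected range from 4 ug/mL to 40 ug/mL.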

Compound 4, half-maximal inhibitory concentration: 6.28 ug/mL
For compound 4 the middle estimate is 1.9-fold (0.28 log units) above the measured one; measured number inside the range.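

In this assay, trifluoromethyl in place of methyl on an aromatic carbon gives a 1.8-fold lower number from compound 3 to compound 4 (0.26 log units; within the scatter), so on this core the change cannot be told apart from the usual scatter of repeated measurements. The same change on the core of compound 1, the pair of compound 1 and compound 2, cannot be read, because both ends of that pair are limits of the assay and not numbers: the limit of > 100 ug/mL in this assay, at which 2 of the 4 values shown sit. The series therefore holds a single readable instance of this change, which shows that the change can be made on the core of compound 3 without a step beyond the scatter, but does not show whether the same holds on another core, and so supports no rule for carrying it from one core to another.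

Open, on these data alone, is whether a different group on this aromatic carbon, such as an amine, a carboxylic acid or a longer alkyl chain, would give a step beyond the scatter on the core of compound 3. Also open is how much each part in which the core of compound 1 differs from the core of compound 3 contributes in this assay, as the compounds shown offer no pair that separates those parts one at a time.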